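From 4-cyanophenyl to pyridin-3-yl on an oxygen

The source may hold more compounds than are shown below. What is called first, only, known or untested is meant among the compounds shown, and "the series" means these compounds.

In a physicochemical assay for metabolic stability, read by HPLC (a higher number here means that the compound lasts longer, a lower number that the compound disappears faster), compound 2 (`Cc1cn([C@H]2C[C@H](N=[N+]=[N-])[C@@H](COP(=O)(O)Oc3ccc(C#N)cc3)O2)c(=O)[nH]c1=O`) gives 7.08 h as its half-life and compound 1 (`Cc1cn([C@H]2C[C@H](N=[N+]=[N-])[C@@H](COP(=O)(O)Oc3ccncc3)O2)c(=O)[nH]c1=O`) gives 8.07 h as its half-life, which places the two within the scatter of each other. Among the compounds with values here, compound 2 therefore stands level with the only other measured compound.

Compound 3 (`Cc1cn([C@H]2C[C@H](N=[N+]=[N-])[C@@H](COP(=O)(O)Oc3cccnc3)O2)c(=O)[nH]c1=O`) has not yet been measured. The change from compound 2 is pyridin-3-yl in place of 4-cyanophenyl on an oxygen and in words it is pyridin-3-yl in place of 4-cyanophenyl on an oxygen.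

Within the data shown here, one measured step bears on this change: a 1.1-fold lower number from compound 1 to compound 2 (0.06 log units; within the scatter) at the same place, with 4-cyanophenyl in place of pyridin-4-yl. That step lies within the scatter. Among the measured compounds shown here, no measured step covers pyridin-3-yl itself, so the evidence is indirect.

No step beyond the scatter is therefore expected in this assay and the estimated step is a 1.1-fold higher number from compound 2 to compound 3 (0.05 log units; within the scatter) with no firm direction. Compound 3 is expected at 8 h with an estimated range of 5 h to 13 h for its half-life. For the measured compounds named here, only two measured values support this range.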

Compound 3, half-life: 3.88 h
The estimate for compound 3 lay 2.1-fold (0.31 log units) above the measured number; the whole stated range lies above it.
By their numbers in this assay, from the lowest: compounds 3, 2 and 1 (each within the scatter of the next, the first and the last beyond it).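

In this assay, within the data shown here, the exchange at the oxygen whose other neighbour is phosphorus gives a 2.1-fold lower number from compound 1 to compound 3 (0.32 log units; beyond the scatter) with pyridin-3-yl in place of pyridin-4-yl, the only step among the three compounds that lies beyond the scatter, and it shows that this position can tell two pyridinyl groups apart even though each brings the same counted heavy atoms and hydrogen-bond acceptors. With pyridin-3-yl in place of 4-cyanophenyl, the series gives a 1.8-fold lower number from compound 2 to compound 3 (0.26 log units; within the scatter), so this exchange does not separate those two groups, and compound 2 remains within the scatter of both compound 1 and compound 3. No measurement shown here accounts for the difference between the two pyridinyl groups.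

Going by these compounds, whether a plain phenyl, or a phenyl carrying a methoxy group or a carboxylic acid, would stand with compound 1 or with compound 3 remains open. Also open, on these data alone, is whether the modest separation of the two pyridinyl groups would persist with an alkyl chain on the same oxygen or on a core other than the one shared here.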